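The source may report more compounds than this note shows. Statements on the series, on what has been measured and on what is new or still open speak of the compounds shown alone.

Measured so far in an ADME assay on MDCK cells (Canis lupus familiaris) for cytotoxicity, read by MTT assay, with a stated time of 24 h; on this read-out lower numbers stand for higher toxicity in this test and higher numbers for lower toxicity in this test:
compound 3 `c1ccc(N2CCN=C2c2ccc(C3=NCCN3)cc2)cc1` gives > 1030000 nM
compound 1 `c1ccc(N2CCN=C2c2ccc(C3=NCCN3c3ccccc3)cc2)cc1` gives > 817000 nM
compound 2 `Fc1ccc(N2CCN=C2c2ccc(C3=NCCN3c3ccc(F)cc3)cc2)cc1` gives 144000 nM

Compound 3 sits at a limit of the assay, not a number. Compound 1 also sits at a limit. Compound 2 gives a true number and is the only one to do so. The step that the two limits leave unreadable from compound 1 to compound 3 cannot be read because the limit of > 1030000 nM in this assay, at which 1 of the 3 values shown sits, and the limit of > 817000 nM in this assay, at which 1 of the 3 values shown sits, both hide the real values. Compound 4 `COc1ccc(N2CCN=C2c2ccc(C3=NCCN3)cc2)cc1` differs from compound 3 by methoxy in place of hydrogen on an aromatic carbon. Among the compounds with values here, no measured step covers that change, so the expectation rests only on compound 3 standing at its limit. The step of an at least 1.2-fold lower number from compound 3 to compound 4 (0.10 log units; that floor lies within the scatter) is estimated to be small or none beyond the scatter. Compound 4 is expected to give about 800000 nM, in a range from 200000 nM to 2000000 nM, quite possibly again reported only as a limit.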

Compound 4, half-maximal cytotoxic concentration: 224000 nM
The estimate for compound 4 lay 3.6-fold (0.55 log units) above the measured number; low and high end bracket the measured number.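

In this assay, the change from phenyl to 4-methoxyphenyl gives an at least 4.5-fold lower number from compound 3 to compound 4 (0.66 log units; beyond the scatter). Compound 3 is only a limit, > 1030000 nM. Within the data shown here, this is the first readable step here, as the only earlier step cannot be read, and it shows that this one small group at this place, para to a large group, is enough to lower the number beyond the scatter. On these data alone, it remains open whether a hydroxyl or an amine at the same place would lower the number as well, and by how much.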